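Hydroxyphenyl position change on the shared core

A few compounds are considered here, and "the series" means these few. Any claim that something is new, unique, unknown or untested is made for them only; others in the source may bear on it.

Compound 1 `Oc1cccc(-c2cc(-c3cccs3)cc(-c3ccccc3O)n2)c1` and compound 2 `Oc1ccc(-c2cc(-c3cccs3)cc(-c3ccccc3O)n2)cc1` were tested in a functional assay on T47D cells (Homo sapiens) for cytotoxicity, read by CCK-8 assay; a lower number here means a stronger inhibitor, a higher number a weaker inhibitor. For compound 1 the result is only a limit of the assay, > 50000 nM. For compound 2 the result is likewise only a limit, > 50000 nM. The two are related by 4-hydroxyphenyl in place of 3-hydroxyphenyl on an aromatic carbon, and the step is a step that the two limits leave unreadable from compound 1 to compound 2. Compound 3 `Oc1cccc(-c2cc(-c3ccccn3)cc(-c3ccccc3O)n2)c1` gives 2560 nM in this assay, so there is an at least 19-fold lower number from compound 1 to compound 3 (1.29 log units; beyond the scatter); the cores of compound 1 and compound 3 differ by pyridin-2-yl in place of thiophen-2-yl on an aromatic carbon. Two of the three results sit at the limit of > 50000 nM in this assay, at which 2 of the 3 values shown sit, so the series is read mainly through compound 3.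

Compound 4 `Oc1ccc(-c2cc(-c3ccccn3)cc(-c3ccccc3O)n2)cc1` is not yet measured. It differs from compound 3 by 4-hydroxyphenyl in place of 3-hydroxyphenyl on an aromatic carbon, the same kind of change as from compound 1 to compound 2, but here meta to a pyridin-2-yl group rather than meta to a thiophen-2-yl group. Going by the values given here, the earlier step cannot be sized from its two limits, so no measured step fixes the direction here. The expected step is a 2.0-fold higher number from compound 3 to compound 4 (0.29 log units; within the scatter), resting on compound 3 at 2560 nM as the only anchor. Compound 4 is thus estimated at 5000 nM in this assay, between 1500 nM and 25000 nM.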

Compound 4, half-maximal inhibitory concentration: > 50000 nM
Compound 4 ended at the assay's limit (the forecaster's own chance of this, stated with the estimate: 25%); middle value at least 10-fold (1.00 log units) away from the limit.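

On the core carrying pyridin-2-yl, 4-hydroxyphenyl in place of 3-hydroxyphenyl gives an at least 19-fold higher number from compound 3 to compound 4 (1.29 log units; beyond the scatter) in this assay, so on this core the position of the hydroxyl group on that phenyl ring decides whether a number is obtained at all. Compound 4 gives > 50000 nM, which is a limit of the assay. The steps from compound 1 to compound 2 and from compound 2 to compound 4 cannot be read, so the same change on the core carrying thiophen-2-yl has no size, and the series does not show that the effect carries from one core to the other, only that the two cores are not told apart at the limit: the limit of > 50000 nM in this assay, at which 3 of the 4 values shown sit.

Going by these compounds alone, compound 3 remains the only compound with a number, so any reading of the pyridin-2-yl core rests on that single value. Open, on these data alone, is whether the 2-hydroxyphenyl group is needed at all, and whether an amine or a carboxylic acid in place of the hydroxyl on the 3-hydroxyphenyl group would keep a number in this assay.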